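Carboxy in Place of the Sulfur-Bearing End Group

A few compounds are considered here, and "the series" means these few. Any claim that something is new, unique, unknown or untested is made for them only; others in the source may bear on it.

Among the measured compounds shown here, compound 2 `N=C(S)CCn1nc(-c2ccccc2)ccc1=O` gives 53.7% in a functional assay on the whole organism (stomach) for inhibition, with Rattus norvegicus as the target, at a dose of 100 mg/kg by the intraduodenal route (a higher number here means more inhibition at the dose given (going by the name of the read-out), a lower number less inhibition), the higher of the two numbers measured so far. Compound 1 `N=C(S)CCCCCCn1nc(-c2ccccc2)ccc1=O` gives 33.9%, and the step of a number 19.8 percentage points higher from compound 1 to compound 2 (beyond the scatter) shortened the chain while leaving the end group untouched. Compound 3 `O=C(O)CCn1nc(-c2ccccc2)ccc1=O` differs from compound 2 in exactly that end group: a group of 3 heavy atoms (1 carbon, 2 oxygen; no ring) in place of a group of 3 heavy atoms (1 carbon, 1 nitrogen, 1 sulfur; no ring), on a saturated chain carbon, two bonds along the chain from an aromatic nitrogen. The carboxy enters on a saturated chain carbon, two bonds along the chain from an aromatic nitrogen, the same position the leaving group occupied. For the measured compounds named here, no measured step swaps this group, so the step from compound 1 to compound 2 bears on compound 3 only in fixing the short chain that compound 3 keeps. Going by the values given here, with no direct precedent, a modest fall in this assay is expected, with a wide range. Compound 3 is expected to give 40%, between 15% and 65%. This is expected to mean a number 13.7 percentage points lower from compound 2 to compound 3 (beyond the scatter).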

Compound 3, a percentage reported as inhibition, in the whole organism at one dose (the size of the read-out at that dose, not a potency): 26.1%
Beside the measured number, compound 3's estimate is 13.9 percentage points above it, within the range that was stated.
By their numbers in this assay, from the lowest: compounds 3 and 1 (each within the scatter of the next); then compound 2.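

Compound 3 shows that, with the short chain held fixed, the end group on this saturated chain carbon matters in its own right: the change to carboxy gives a number 27.6 percentage points lower from compound 2 to compound 3 (beyond the scatter) in this assay, so the gain seen on shortening the chain does not carry over to every end group. The short chain alone therefore does not secure the higher number in this assay, and the carboxy compound stands level with the long-chain compound, with a number 7.8 percentage points lower from compound 1 to compound 3 (within the scatter) as the printed step. No measurement offered here explains why the end group has this effect.

The compounds shown leave open how a carboxy end group would behave on a longer chain, where the two changes could be separated. They also leave open whether an amine or a primary amide at this position would give a number nearer to that of compound 2 or to that of compound 3.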